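The source may report more compounds than this note shows. Statements on the series, on what has been measured and on what is new or still open speak of the compounds shown alone.

Compound 1 `O=C(O)/C=C/c1ccncc1-c1ccc2ccccc2c1` was measured in a functional assay on KB cells (Homo sapiens) for inhibition, read by sulforhodamine B assay, with a stated time of 72 h; a lower number here means a stronger inhibitor of growth, a higher number a weaker inhibitor of growth; compound 1 gives only a limit of the assay, > 10000 nM.
Compound 2 `O=C(/C=C/c1ccncc1-c1ccc2cc[nH]c2c1)N1CCOCC1` was measured in this assay; compound 2 gives only a limit of the assay, > 10000 nM.
Compound 3 `O=C(/C=C/c1ccncc1-c1ccc2ccccc2c1)N1CCOCC1` was measured in this assay; compound 3 gives only a limit of the assay, > 10000 nM.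

The change from compound 3 to compound 1 is hydroxy in place of morpholin-4-yl on a carbonyl carbon. In this assay it made a step that the two limits leave unreadable from compound 3 to compound 1, because of the limit of > 10000 nM in this assay, at which 3 of the 3 values shown sit. The difference between the core of compound 2 and the core of compound 3 is not broken down here. Compound 4 `O=C(O)/C=C/c1ccncc1-c1ccc2cc[nH]c2c1` has not yet been measured in this assay. It stands to compound 2 as compound 1 stands to compound 3: the same change, (hydroxy in place of morpholin-4-yl on a carbonyl carbon). In this assay the step that the limit leaves unreadable from compound 2 to compound 4 is expected to be small, an expectation resting on the unreadable step that the two limits leave unreadable from compound 3 to compound 1 and on the fact that compound 2 itself shows only a limit, > 10000 nM. Compound 4 is therefore estimated at 20000 nM, most likely again reported only as a limit, with a range from 5000 nM to 80000 nM.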

Compound 4, concentration for 50% growth inhibition: > 10000 nM
Compound 4 was reported as a limit; the forecaster's own chance of this, stated with the estimate: 85%; the middle value is on the limit's open side.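

No step can be read from compound 2 to compound 4, because both give only a limit: the limit of > 10000 nM in this assay, at which 4 of the 4 values shown sit.
In this assay the compounds shown leave open whether hydroxy and morpholin-4-yl differ at all, and whether the two cores do.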